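Swapping a Chain Methyl for Methoxy at the Aromatic Ether

The compounds below may be only part of what the source reports. "The series", "measured", "known", "first", "only" and "open" are said of these compounds alone.

compound 1 `CCOc1cc(C)c(-c2cccc(CNc3ccc(OCC(=O)O)c(F)c3)c2)c(C)c1` — 24.2 nM
compound 2 `CCCOc1cc(C)c(-c2cccc(CNc3ccc(OCC(=O)O)c(F)c3)c2)c(C)c1` — 38.7 nM

In a functional assay on CHO cells for agonist activity at Free fatty acid receptor 1 (Homo sapiens), read by FLIPR and calcium flux (a higher number here means that more compound is needed for the effect, a lower number that less compound is needed), compound 1 gives 24.2 nM and compound 2 gives 38.7 nM. Compound 2 holds the higher of the two numbers shown, but only by a 1.6-fold higher number from compound 1 to compound 2 (0.20 log units; within the scatter), so the two compounds cannot be told apart on this evidence.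

Compound 3 `COCCOc1cc(C)c(-c2cccc(CNc3ccc(OCC(=O)O)c(F)c3)c2)c(C)c1` takes compound 2 one step further along the same chain: methoxy in place of methyl on a saturated chain carbon, two bonds along the chain from an oxygen on an aromatic ring. Within the data shown here, the only measured step that bears on this position is the one from compound 1 to compound 2, where adding a carbon at the same place gave a 1.6-fold higher number from compound 1 to compound 2 (0.20 log units; within the scatter). Among the measured compounds shown here, replacing that terminal methyl with methoxy keeps the chain length and adds an ether oxygen, a change for which no direct precedent exists here, so the expected step is small, a 1.0-fold higher number from compound 2 to compound 3 (0.01 log units; within the scatter), with no direction beyond the scatter. Compound 3 is therefore estimated at 40 nM, within a range of 15 nM to 110 nM.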

Compound 3, half-maximal effective concentration: 51.6 nM
The estimate for compound 3 lay 1.3-fold (0.11 log units) below the measured number; the measured number falls inside the stated range.
By their numbers in this assay, from the lowest: compounds 1, 2 and 3 (each within the scatter of the next, the first and the last beyond it).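

In this assay, methoxy in place of methyl on this chain carbon gives a step too small to read (a 1.3-fold higher number from compound 2 to compound 3 (0.12 log units; within the scatter)), so adding an ether oxygen here cannot be told apart from leaving the propoxy chain unchanged. Among these compounds, what is new comes from the wider comparison: methoxy in place of hydrogen at the same carbon (a 2.1-fold higher number from compound 1 to compound 3 (0.33 log units; beyond the scatter)) is the first step at this position to pass the scatter, although only modestly. No supporting measurement bears on why the number moves.

With the 2-methoxyethoxy group as the only ether-containing chain shown, the separate contributions of chain length and the added oxygen remain unresolved. A butoxy chain, or a chain ending in a hydroxyl or an amine, would show how this position responds to other ends.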